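The source may hold more compounds than are shown below. What is called first, only, known or untested is meant among the compounds shown, and "the series" means these compounds.

Measured compounds:
compound 1 `COc1cc(-c2ccnc3cc(-c4ccc(F)cc4)nn23)cc(OC)c1OC` — 5840 nM
compound 2 `COc1cc(-c2ccnc3cc(-c4ccc(Cl)cc4)nn23)cc(OC)c1OC` — 1490 nM
compound 3 `COc1cc(-c2ccnc3cc(-c4ccc5cc[nH]c5c4)nn23)cc(OC)c1OC` — 125 nM

In a functional assay on HeLa cells (Homo sapiens) for inhibition, read by CCK-8 assay, with a stated time of 48 h (a higher number here means a weaker inhibitor, a lower number a stronger inhibitor), compound 1 stands with the highest number of the three; the nearest is compound 2, reached by a 3.9-fold lower number from compound 1 to compound 2 (0.59 log units; beyond the scatter), and the furthest is compound 3, reached by a 47-fold lower number from compound 1 to compound 3 (1.67 log units; beyond the scatter). Compound 4 `C=Cc1ccc(-c2cc3nccc(-c4cc(OC)c(OC)c(OC)c4)n3n2)cc1` differs from compound 1 as follows: vinyl in place of fluoro on an aromatic carbon. Within the data shown here, two measured steps bear on this change, both replacing the fluoro of compound 1 on the same ring of the shared core. The chloro for fluoro exchange gives a 3.9-fold lower number from compound 1 to compound 2 (0.59 log units; beyond the scatter), a modest step; the 1H-indol-6-yl for 4-fluorophenyl exchange gives a 47-fold lower number from compound 1 to compound 3 (1.67 log units; beyond the scatter), a large step, and a 12-fold lower number from compound 2 to compound 3 (1.08 log units; beyond the scatter) shows the same ordering. Both replacements of fluoro lowered the number. Vinyl is neither a halogen nor a second ring, so no direct precedent exists among the measured compounds. The expectation is a step of the size of a 2.9-fold lower number from compound 1 to compound 4 (0.47 log units; beyond the scatter), toward a lower number, beyond the scatter but closer to the modest step than to the large one. Compound 4 is therefore expected at 2000 nM, with a range of 600 nM to 6000 nM.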

Compound 4, half-maximal inhibitory concentration: 882 nM
For compound 4 the middle estimate is 2.3-fold (0.36 log units) above the measured one, and the stated range covers the measured number.
By their numbers in this assay, from the lowest: compound 3; then compounds 4 and 2 (each within the scatter of the next); then compound 1.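

In this assay, the gain over fluoro at this position does not need a halogen or a second ring: vinyl also lowers the number (a 6.6-fold lower number from compound 1 to compound 4 (0.82 log units; beyond the scatter)). Vinyl and chloro cannot be separated here (a 1.7-fold lower number from compound 2 to compound 4 (0.23 log units; within the scatter)), so the larger entering group, with its double bond outside aromatic rings, gives no measurable change from chloro. The 4-vinylphenyl compound still falls short of the 1H-indol-6-yl compound (a 7.1-fold higher number from compound 3 to compound 4 (0.85 log units; beyond the scatter)), which leaves compound 3 as the only one in the set with a large step from compound 1.

No measurement at hand accounts for these steps. On these data alone, it remains open whether the double bond itself matters, which ethyl in place of vinyl would test, and how an amine or a carboxylic acid at this position would compare.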